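Trimming the sulfonamide amine in a bis-sulfonyl series

The source may hold more compounds than are shown below. What is called first, only, known or untested is meant among the compounds shown, and "the series" means these compounds.

Compound 1 `CCCN(CCC)S(=O)(=O)c1ccc(S(=O)(=O)N2CCC[C@@H](C(=O)OCC)C2)cc1` carries a dipropylsulfamoyl group on one side of its shared core and an ethyl ester on the piperidine side. In a functional assay on MIA PaCa-2 cells (Homo sapiens) for inhibition, read by MTT assay, with a stated time of 7 days (a higher number here means a weaker inhibitor, a lower number a stronger inhibitor), compound 1 gives 2300 nM, the lowest of the two numbers recorded. Compound 2 `CCN(CC)S(=O)(=O)c1ccc(S(=O)(=O)N2CCC[C@@H](C(=O)NC)C2)cc1`, with a diethylamino group and a methylamide in place of the ester, gives 8600 nM in this assay, a gap beyond the usual scatter. Compound 3 `CCOC(=O)[C@@H]1CCCN(C(=O)c2ccc(S(=O)(=O)N(CC)CC)cc2)C1`, in which the second sulfonyl is replaced by a carbonyl, returns only a limit in this assay, > 10000 nM, and one of the three values reported sits at it (the limit of > 10000 nM in this assay, at which 1 of the 3 values shown sits).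

Compound 4 `CCOC(=O)[C@@H]1CCCN(S(=O)(=O)c2ccc(S(=O)(=O)N(CC)C(C)C)cc2)C1` differs from compound 1 in one place: ethyl(isopropyl)amino in place of dipropylamino on a sulfonyl sulfur. Among the measured compounds shown here, since no pair of measured compounds isolates a change of this kind, the expectation rests on compound 1 alone. Compound 4 is expected to land close to compound 1, a step of a 1.5-fold higher number from compound 1 to compound 4 (0.18 log units; within the scatter) that stays within or just at the scatter, giving an estimated 3500 nM with a range from 1200 nM to 10000 nM.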

Compound 4, half-maximal inhibitory concentration: 1000 nM
Beside the measured number, compound 4's estimate is 3.5-fold (0.54 log units) above it; the whole stated range lies above it.
By their numbers in this assay, from the lowest: compound 4; then compound 1; then compound 2. At a limit, above all of these: compound 3.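

In this assay, among the compounds shown here, exchanging dipropylamino for ethyl(isopropyl)amino on a sulfonyl sulfur gives a 2.3-fold lower number from compound 1 to compound 4 (0.36 log units; beyond the scatter) and is the first change here made in one place alone. It shows that this position affects the read-out, although the step is modest, and that the ethyl(isopropyl)sulfamoyl group is tolerated with the ethyl ester kept in place. Nothing among the measurements shown explains the step.

This single step cannot separate the shorter chain from the branched one, so the contribution of each remains unresolved. Also open, on these data alone, is how a longer chain such as dibutylamino, a smaller dimethylamino group, or a carboxylic acid in place of the ethyl ester would behave on this core.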